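Fluoro for methyl: an expected rise in the number

A few compounds are considered here, and "the series" means these few. Any claim that something is new, unique, unknown or untested is made for them only; others in the source may bear on it.

Measured in a functional assay on MCF7 cells (Homo sapiens) for inhibition, read by MTT assay, with a stated time of 48 h; a lower number here means a stronger inhibitor, a higher number a weaker inhibitor:
- Compound 1 `O=C1N/C(=N\Cc2ccc(Cl)cc2)S/C1=C1/CCNC(=O)c2[nH]ccc21`: > 100000 nM, a limit of the assay
- Compound 2 `O=C1N/C(=N\Cc2ccccc2Cl)S/C1=C1/CCNC(=O)c2[nH]ccc21`: 21200 nM
- Compound 3 `Cc1ccc(C/N=C2\NC(=O)/C(=C3\CCNC(=O)c4[nH]ccc43)S2)cc1`: 8150 nM

Compound 3 has the lowest number, and compound 2 is its nearest neighbour. Compound 4 `O=C1N/C(=N\Cc2ccc(F)cc2)S/C1=C1/CCNC(=O)c2[nH]ccc21` carries fluoro in place of methyl on an aromatic carbon, para to a large group (fluoro in place of methyl on an aromatic carbon). The closest measured change is an at least 12-fold lower number from compound 1 to compound 3 (1.08 log units; beyond the scatter), with methyl in place of chloro. A smaller change, a 2.6-fold lower number from compound 2 to compound 3 (0.42 log units; beyond the scatter), also replaces a chlorophenyl group. Neither tests fluoro, so only a modest rise in the number is expected. The expected step is a 2.7-fold higher number from compound 3 to compound 4 (0.43 log units; beyond the scatter). For compound 4 the estimate is 22000 nM, with an expected range of 7000 nM to 90000 nM.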

Compound 4, half-maximal inhibitory concentration: 43100 nM
Estimate against measurement, compound 4: 2.0-fold (0.29 log units) below, within the range that was stated.
By their numbers in this assay, from the lowest: compound 3; then compound 2; then compound 4. At a limit, above all of these: compound 1.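

In this assay, going by these compounds alone, a 5.3-fold higher number from compound 3 to compound 4 (0.72 log units; beyond the scatter) gives the first direct reading of fluoro against methyl on this aromatic carbon, para to a large group, and methyl holds the lower number. Replacing the 2-chlorophenyl group with 4-fluorophenyl gives a 2.0-fold higher number from compound 2 to compound 4 (0.31 log units; beyond the scatter). Fluoro in place of chloro gives an at least 2.3-fold lower number from compound 1 to compound 4 (0.36 log units; beyond the scatter), a step that rests on a limit for compound 1 and not on a number: the limit of > 100000 nM in this assay, at which 1 of the 4 values shown sits.

On these data alone, whether a methoxy group or an amine on this carbon would fall below methyl stays open, as does the effect of a longer chain carrying the ring.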